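The compounds below may be only part of what the source reports. "The series", "measured", "known", "first", "only" and "open" are said of these compounds alone.

In a functional assay on HL-60 cells (Homo sapiens) for antiproliferative activity, read by MTT assay, with a stated time of 72 h (a higher number here means a weaker inhibitor, a lower number a stronger inhibitor), compound 1 `COc1ccc(OC)c(-c2c(C(=O)c3cc(OC)c(OC)c(OC)c3)sc3ccccc23)c1` gives > 10000 nM as its reading, which is a limit and not a number. Among the compounds with values here, compound 2 `COc1ccc(Nc2c(C(=O)c3cc(OC)c(OC)c(OC)c3)sc3ccccc23)cc1` gives 3700 nM as the only actual number so far. Within the data shown here, the one measured step is an at least 2.7-fold lower number from compound 1 to compound 2 (0.43 log units; beyond the scatter) and it exchanges a whole substituent on the shared core, so it sets no size for the change at hand. Compound 3 `CCOc1ccc(Nc2c(C(=O)c3cc(OC)c(OC)c(OC)c3)sc3ccccc23)cc1` carries 4-ethoxyphenyl where compound 2 has 4-methoxyphenyl, with methyl in place of hydrogen on a saturated chain carbon bound to an oxygen on an aromatic ring is the whole difference. Among the measured compounds shown here, no measured step covers methoxy to ethoxy, so in this assay a step within the scatter is expected, with no firm direction. The expected step is a 1.2-fold lower number from compound 2 to compound 3 (0.09 log units; within the scatter) in this estimate. For compound 3 the estimated value is 3000 nM with 1200 nM to 8000 nM as the expected range.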

Compound 3, half-maximal inhibitory concentration: 500 nM
Compound 3: middle estimate off by 6.0-fold (0.78 log units), on the high side; measured number outside the range, below it.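

In this assay, this position on the 4-alkoxyphenyl group responds to a very small change: one methyl in place of hydrogen on a saturated chain carbon bound to an oxygen on an aromatic ring gives a 7.4-fold lower number from compound 2 to compound 3 (0.87 log units; beyond the scatter), a size that the earlier whole-substituent exchange could not set. Replacing 2,5-dimethoxyphenyl with (4-ethoxyphenyl)amino on an aromatic carbon gives an at least 20-fold lower number from compound 1 to compound 3 (1.30 log units; beyond the scatter). The reading for compound 1 is a limit and not a number, so that step gives only a floor: the limit of > 10000 nM in this assay, at which 1 of the 3 values shown sits.

With only methoxy and ethoxy shown, it remains open whether a longer chain such as propoxy or butoxy extends this step, or reverses it. Also open, going by these compounds, is how a chain ending in an amine or a carboxylic acid would read at this position.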